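A carbonyl returns to the shared core

The compounds below may be only part of what the source reports. "The series", "measured", "known", "first", "only" and "open" are said of these compounds alone.

Of the compounds shown here, three with one shared core have been measured in a toxicity assay on CCRF-CEM cells (Homo sapiens) for cytotoxicity; on this read-out higher numbers stand for lower toxicity in this test and lower numbers for higher toxicity in this test. Compound 1 `COC(=O)c1cccc2c1nc(-c1c(F)cccc1F)n2Cc1c(F)cccc1F`, which carries methoxycarbonyl, gives 57.7 uM. Compound 2 `Oc1cccc2c1nc(-c1c(F)cccc1F)n2Cc1c(F)cccc1F`, which carries hydroxy instead, reads > 100 uM, a limit of the assay and not a number. Compound 3 `CN(C)c1cccc2c1nc(-c1c(F)cccc1F)n2Cc1c(F)cccc1F`, which carries dimethylamino, reads > 100 uM, again only a limit. Compound 3 therefore stands at the limit of > 100 uM in this assay, at which 2 of the 3 values shown sit.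

Compound 4 `CN(C)C(=O)c1cccc2c1nc(-c1c(F)cccc1F)n2Cc1c(F)cccc1F` has dimethylcarbamoyl in place of dimethylamino on an aromatic carbon. Among the measured compounds shown here, two measured steps bear on this change: an at least 1.7-fold higher number from compound 1 to compound 2 (0.23 log units; that floor lies within the scatter) and an at least 1.7-fold higher number from compound 1 to compound 3 (0.23 log units; that floor lies within the scatter). Neither shows a firm size, so both offer only weak guidance. Compound 4 carries a carbonyl, as does compound 1 at 57.7 uM, so a modest move toward lower numbers seems more likely than a move toward higher ones. The expected step is an at least 1.2-fold lower number from compound 3 to compound 4 (0.09 log units; that floor lies within the scatter), and it may not be readable if another limit results. For compound 4 the estimate is 80 uM, with an expected range from 35 uM to 140 uM.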

Compound 4, half-maximal toxic concentration: 80.1 uM
Estimate against measurement, compound 4: 1.0-fold (0.00 log units) below, within the range that was stated.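

Compound 4 gives this position a second real number in this assay, so two carbonyl groups can now be compared directly: dimethylamino in place of methoxy on the carbonyl carbon gives a 1.4-fold higher number from compound 1 to compound 4 (0.14 log units; within the scatter). Against the compounds without a carbonyl, the steps are an at least 1.2-fold lower number from compound 3 to compound 4 (0.09 log units; that floor lies within the scatter) and an at least 1.2-fold lower number from compound 2 to compound 4 (0.09 log units; that floor lies within the scatter), so neither shows a firm drop. Among the compounds shown, the two with a carbonyl give numbers, while compound 2 and compound 3, which have none, each remain at a limit of the assay: the limit of > 100 uM in this assay, at which 2 of the 4 values shown sit.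

Among the compounds shown here, whether the carbonyl itself sets this difference stays open, since no step here has a firm size beyond the scatter. A carboxylic acid or an amine with a longer chain on the same aromatic carbon could show whether this split between numbers and limits holds.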